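Methyl to Bromo on the Aryl Ring: an Expected Outcome

The source may report more compounds than this note shows. Statements on the series, on what has been measured and on what is new or still open speak of the compounds shown alone.

Of the compounds shown here, three sharing one core have been tested in a functional assay on the whole organism (strain Wistar) for inhibition, with Rattus norvegicus as the target, read by paw edema, with stated times of 30 min and 120 min, at a dose of 10 mg/kg by the oral route; a lower number here means less inhibition, a higher number more inhibition at the dose given (going by the name of the read-out). Compound 1 `Cc1ccc(/N=C2/NC(=O)/C(=C/c3ccccn3)S2)cc1` gives 43.8% in this assay. Compound 2 `COc1ccc(/N=C2\NC(=O)/C(=C/c3ccccn3)S2)cc1` gives 39.1% in this assay, and compound 3 `O=C1N/C(=N/c2cccc([N+](=O)[O-])c2)S/C1=C\c1ccccn1` gives 43.5% in this assay; both of these numbers lie within the usual scatter of the value of compound 1, so the three read as alike. Compound 4 `O=C1N/C(=N/c2ccc(Br)cc2)S/C1=C\c1ccccn1` differs from compound 1 by bromo in place of methyl on an aromatic carbon. For the measured compounds named here, no measured pair here shows the effect of a single change, and the three measured numbers stay close despite different groups on the same ring. The step of a number 1.8 percentage points lower from compound 1 to compound 4 (within the scatter) is therefore expected to stay within the scatter. Compound 4 is expected to give 42%, with a range from 30% to 55%.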

Compound 4, a percentage reported as inhibition, in the whole organism at one dose (the size of the read-out at that dose, not a potency): 30.4%
Compound 4: middle estimate off by 11.6 percentage points, on the high side; the measured number falls inside the stated range.
By their numbers in this assay, from the lowest: compounds 4, 2, 3 and 1 (each within the scatter of the next, the first and the last beyond it).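

In this assay, bromo in place of methyl on an aromatic carbon para to a large group gives a number 13.4 percentage points lower from compound 1 to compound 4 (beyond the scatter), so this change is not silent. The earlier compounds shown here, with no single-change pair among them, could not show that one swap at this place moves the number beyond the scatter. Nothing at hand bears on why the number falls.

As far as these compounds go, what chloro, an amine or a carboxylic acid would give at this same place remains open. So does whether the step holds on the other substituted rings in the series.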